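The source may report more compounds than this note shows. Statements on the series, on what has been measured and on what is new or still open speak of the compounds shown alone.

Working notes on the series. In a functional assay on MDA-MB-468 cells (Homo sapiens) for inhibition, read by MTT assay (on this read-out higher numbers stand for weaker inhibition of growth and lower numbers for stronger inhibition of growth), compound 1 `CC1=C(/C=C/C(C)=C/C=C/C(C)=C\C(=O)Nc2ccccc2)C(C)(C)CCC1n1ccnc1` gives 2540 nM and compound 2 `CC1=C(/C=C/C(C)=C/C=C/C(C)=C\C(=O)Nc2ccc(O)cc2)C(C)(C)CCC1n1ccnc1` gives 6830 nM. For the measured compounds named here, compound 2 therefore holds the higher of the two numbers so far, meaning the weaker inhibition of growth.

The next compound, compound 3 `CC1=C(/C=C/C(C)=C/C=C/C(C)=C\C(=O)NCc2cccc(F)c2)C(C)(C)CCC1n1ccnc1`, departs from compound 2 on the amide-type nitrogen: 3-fluorobenzyl in place of 4-hydroxyphenyl on an amide-type nitrogen. The 4-hydroxyphenyl leaves and 3-fluorobenzyl enters.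

Going by the values given here, only one measured step bears on this change: a 2.7-fold higher number from compound 1 to compound 2 (0.43 log units; beyond the scatter), a modest step, with hydroxy in place of hydrogen on an aromatic carbon. Compound 3 carries no hydroxy either, so that step, read backwards, points to a lower number than that of compound 2, of similar modest size. Among the compounds with values here, no measured compound carries 3-fluorobenzyl, so the data say nothing directly about that part of the change, and the direction stays tentative.

The expected move in this assay is a 2.1-fold lower number from compound 2 to compound 3 (0.33 log units; beyond the scatter), a modest estimated step toward stronger inhibition of growth. For compound 3 the estimated value is 3200 nM, with an expected range of 1000 nM to 9000 nM.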

Compound 3, concentration for 50% growth inhibition: 3090 nM
Estimate against measurement, compound 3: 1.0-fold (0.02 log units) above, and the stated range covers the measured number.
By their numbers in this assay, from the lowest: compounds 1 and 3 (each within the scatter of the next); then compound 2.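

In this assay, moving the amide-type nitrogen from 4-hydroxyphenyl to 3-fluorobenzyl gives a 2.2-fold lower number from compound 2 to compound 3 (0.34 log units; beyond the scatter), so this position accepts a larger change than the hydroxy step alone and still gives modestly stronger inhibition of growth. Taking phenyl as the starting group instead, the same position gives a 1.2-fold higher number from compound 1 to compound 3 (0.09 log units; within the scatter); this pair cannot be told apart on this read-out, and among the three groups shown on this nitrogen only the 4-hydroxyphenyl of compound 2 stands apart from the other two. Nothing at hand gives a reason for either step.

Compound 3 differs from compound 1 in both the added carbon link and the fluorine, so the compounds shown do not separate the two, and a plain benzyl or a 3-fluorophenyl on the same nitrogen would be needed to part them. From the compounds shown here alone, it also remains open how this nitrogen responds to a longer chain such as 2-phenylethyl, or to an aromatic ring carrying an amine or a carboxylic acid.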